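Isopropoxy for methoxy on the urea arm

A few compounds are considered here, and "the series" means these few. Any claim that something is new, unique, unknown or untested is made for them only; others in the source may bear on it.

Three members of the series, compound 1 `COc1ccc(-c2cc(NNC(=O)Nc3cc(Cl)nc(OC)c3)nc3c2cnn3C)cc1`, compound 2 `COc1cc(NC(=O)NNc2cc(-c3ccc(F)cc3)c3cnn(C)c3n2)cc(Cl)n1` and compound 3 `Cc1nn(C)c2nc(NNC(=O)Nc3cc(Cl)nc(Cl)c3)cc(C3CC3)c12`, have been run in an assay on isolated protein for binding affinity to sphingosine 1-phosphate receptor 2 (Homo sapiens), read by surface plasmon resonance; a lower number here means tighter binding, a higher number weaker binding. Compound 1 gives 1980 nM, compound 2 gives 1650 nM and compound 3 gives 3650 nM. Compound 1 stands second highest of the three numbers; its nearest neighbour is compound 2, with a 1.2-fold lower number from compound 1 to compound 2 (0.08 log units; within the scatter), and compound 3 lies furthest, though the two values still sit within the usual scatter of the assay.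

Compound 4 `COc1ccc(-c2cc(NNC(=O)Nc3cc(Cl)nc(OC(C)C)c3)nc3c2cnn3C)cc1` differs from compound 1 by isopropyl in place of methyl on an oxygen on an aromatic ring. Among the measured compounds shown here, the only single-place step measured, from compound 1 to compound 2, alters the other aromatic end of the shared core and is within the scatter; no measured pair varies the group on the oxygen on the aromatic ring. No step beyond the scatter is therefore expected in this assay, a 1.0-fold higher number from compound 1 to compound 4 (0.00 log units; within the scatter). Compound 4 is estimated at 2000 nM, within a range of 900 nM to 4500 nM.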

Compound 4, dissociation constant: 2320 nM
Estimate against measurement, compound 4: 1.2-fold (0.06 log units) below, and the stated range covers the measured number.
By their numbers in this assay, from the lowest: compounds 2, 1, 4 and 3 (each within the scatter of the next, the first and the last beyond it).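

In this assay, among the compounds shown here, methoxy to isopropoxy on the urea arm gives a 1.2-fold higher number from compound 1 to compound 4 (0.07 log units; within the scatter), the first measured step at the group on the oxygen on an aromatic ring. Methyl and isopropyl there cannot be told apart, so this position takes 3 heavy atoms in place of 1 with no step beyond the scatter. Nothing available bears on the reason for this result. Open, on these data alone, is whether a longer chain or an amine on that oxygen would stay within the scatter of compound 1, and whether isopropoxy behaves alike with the fluorophenyl group of compound 2.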